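The source may report more compounds than this note shows. Statements on the series, on what has been measured and on what is new or still open speak of the compounds shown alone.

The study centres on a single read-out, a functional assay on the whole organism (artery, strain albino) with Rattus norvegicus as the target, with a stated time of 600 min, at a dose of 10 mg/kg by the oral route (a higher number here means more inhibition at the dose given (going by the name of the read-out), a lower number less inhibition), for two measured compounds and one that has not yet been tested. Compound 1 `COc1ccc(C2N=C(SCc3ccccc3Cl)NC(C)=C2C(=O)Nc2ccc(F)cc2)cc1OC` in this assay gives 30.3%. Compound 2 `CC1=C(C(=O)Nc2ccc(Br)cc2)C(c2ccc(Cl)cc2Cl)N=C(SCc2ccccc2)N1` in this assay gives 17.4%. Compound 2 stands lowest of the two numbers; its nearest neighbour is compound 1, whose number lies higher by a margin that is beyond the scatter. The two measured compounds differ from each other in several places at once, so no single step can be read off between them.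

Compound 3 `CC1=C(C(=O)Nc2ccc(Br)cc2)C(c2ccc(Cl)cc2Cl)N=C(SCc2ccc(F)cc2)N1` differs from compound 2 by fluoro in place of hydrogen on an aromatic carbon. Among the measured compounds shown here, nothing among the measured compounds shows what such a change does to this assay, so the expectation rests on the small size of the change alone. The step that the estimate means, a number 2.6 percentage points higher from compound 2 to compound 3 (within the scatter), is expected to be small, in no sure direction, and within the scatter. Compound 3 is therefore expected to give about 20% in this assay, with a range from 5% to 36%.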

Compound 3, a percentage reported as inhibition, in the whole organism at one dose (the size of the read-out at that dose, not a potency): 33.3%
Compound 3: middle estimate off by 13.3 percentage points, on the low side; low and high end bracket the measured number.
By their numbers in this assay, from the lowest: compound 2; then compounds 1 and 3 (each within the scatter of the next).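

Within the benzylsulfanyl side chain, phenyl to 4-fluorophenyl is the only single change that can be read in this assay, and it gives a number 15.9 percentage points higher from compound 2 to compound 3 (beyond the scatter) at the dose given. This shows that the position, on an aromatic carbon para to a large group, is not silent in this read-out: one fluoro in place of hydrogen, with the rest of compound 2 unchanged, moves the inhibition beyond the scatter, which the two earlier compounds, differing in several places at once, could not show. No measurement shown bears on why the step arises.

As far as these compounds go, it remains open whether the rise belongs to fluoro itself or would also come with another group at this place, such as chloro, methoxy, an amine or a carboxylic acid. From the compounds shown here alone, it is equally open whether the same change would give a step of similar size on a compound with other groups on the shared core, since this single pair is all that can be read for it.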